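The source may report more compounds than this note shows. Statements on the series, on what has been measured and on what is new or still open speak of the compounds shown alone.

Compound 2 `CSc1cc(C)nc(SC)c1NC(=O)N(Cc1ccccc1)Cc1cccc(-c2cc[nH]n2)c1` gives in a functional assay on a cell-free system (plasma) with sterol O-acyltransferase, Soat (Rattus norvegicus) as the target (a higher number here means that more compound is needed for the effect, a lower number that less compound is needed), 0.046 mg/kg. Compound 3 `COc1ccccc1CN(Cc1cccc(-c2cc[nH]n2)c1)C(=O)Nc1c(SC)cc(C)nc1SC` in this assay gives > 0.1 mg/kg, which is a limit of the assay and not a number. Compound 1 `Cc1cc(C)c(NC(=O)N(Cc2ccc(-c3ccccc3)s2)C2CCCCCC2)c(C)c1` in this assay gives < 1 mg/kg, again a limit only. For the measured compounds named here, the one measured step, an at least 2.1-fold higher number from compound 2 to compound 3 (0.33 log units; beyond the scatter), shows that adding a methoxy to the benzyl ring weakened the effect, as recorded at the limit of > 0.1 mg/kg in this assay, at which 1 of the 3 values shown sits. Compound 4 `CSc1cc(C)nc(SC)c1NC(=O)N(Cc1ccc(N(C)C)cc1)Cc1cccc(-c2cc[nH]n2)c1` carries 4-(dimethylamino)phenyl in place of 2-methoxyphenyl on a saturated chain carbon bound to an amide-type nitrogen. Going by the values given here, no measured step covers this exchange, so its direction against compound 3 cannot be read from the data. Since compound 2 with the plain benzyl gave 0.046 mg/kg, compound 4 is expected to land near 0.1 mg/kg, within 0.03 mg/kg to 0.4 mg/kg. The expected step is a number no higher from compound 3 to compound 4 (the limit leaves the size open).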

Compound 4, dose for half-maximal effect: < 0.1 mg/kg
Compound 4 gave a limit, no number; the forecaster's own chance of this, stated with the estimate: 40%; the middle value sits exactly at the limit.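

In this assay the exchange at this place gives a number no higher from compound 3 to compound 4 (the limit leaves the size open), so a substituent on this ring does not always carry the loss that the methoxy group brought in compound 3. The value of compound 4 is a limit and not a number. From the compounds shown here alone, the step from compound 2 to compound 4 cannot be read, so any cost of dimethylamino against the plain benzyl stays unknown.

The exchange alters both the group and its place on the ring, and the compounds shown do not separate the two. A 4-methoxybenzyl or a 4-carboxybenzyl at this place would bear on that question.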